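From 2-methylphenyl to 2-fluorophenyl: working notes

The compounds below may be only part of what the source reports. "The series", "measured", "known", "first", "only" and "open" are said of these compounds alone.

Measured in a functional assay on KB cells (Homo sapiens) for antiproliferative activity, read by sulforhodamine B assay, with a stated time of 3 days; a lower number here means that less compound is needed, a higher number that more compound is needed for the effect:
- compound 1 `CCC1=C(O)c2c(oc(-c3ccccc3)cc2=O)C(CC)(CC)C1=O`: > 236 uM, a limit
- compound 2 `CCCc1ccc(-c2cc(=O)c3c(o2)C(CC)(CC)C(=O)C(CC)=C3O)cc1`: > 53 uM, a limit
- compound 3 `CCC1=C(O)c2c(oc(-c3ccccc3C)cc2=O)C(CC)(CC)C1=O`: 40.9 uM

Going by the values given here, compound 3 holds the only true number in this small set, since the other two values are limits. Compound 4 `CCC1=C(O)c2c(oc(-c3ccccc3F)cc2=O)C(CC)(CC)C1=O` carries fluoro in place of methyl on an aromatic carbon, ortho to a large group: fluoro in place of methyl on an aromatic carbon.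

The measured step closest to this change is an at least 5.7-fold lower number from compound 1 to compound 3 (0.76 log units; beyond the scatter), which places methyl on an aromatic carbon in place of hydrogen. By contrast, an at least 1.2-fold lower number from compound 2 to compound 3 (0.11 log units; that floor lies within the scatter) has a floor too small to set a size, and a step that the two limits leave unreadable from compound 1 to compound 2 cannot be read. Among the compounds with values here, no fluoro compound has been measured, so the direction rests on that single methyl step, part of which should be given back once the methyl leaves. On that basis, a 2.2-fold higher number from compound 3 to compound 4 (0.34 log units; beyond the scatter) is the expected step in this assay, towards a higher number and modest in size. For compound 4 the estimate is 90 uM, with an expected range of 35 uM to 240 uM.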

Compound 4, concentration for half-maximal effect: > 56.2 uM
Compound 4 gave a limit, no number; the forecaster's own chance of this, stated with the estimate: 40%; the middle value does not contradict the limit.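

In this assay, fluoro on this aromatic carbon, ortho to a large group, leaves compound 4 as a limit and not a number: the limit of > 56.2 uM in this assay, at which 1 of the 4 values shown sits. Fluoro in place of methyl gives an at least 1.3-fold higher number from compound 3 to compound 4 (0.13 log units; that floor lies within the scatter), so this change is not shown to go beyond the scatter, although methyl remains the only one of the three groups tried here (hydrogen, methyl, fluoro) that gives a true number. The steps to compound 4 from compound 1 and from compound 2 join limit to limit and cannot be read.

Open, on these data alone, is whether a number at this place requires methyl itself or would also appear with chloro, methoxy or an ethyl chain. As far as these compounds go, the size of the fluoro step also stays open while compound 4 has only a limit.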